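Series notes: replacing the pyrimidinyl arm on the saturated ring carbon

The source may hold more compounds than are shown below. What is called first, only, known or untested is meant among the compounds shown, and "the series" means these compounds.

The shared core carries an aminopyrimidinylmethyl-dimethoxyphenyl acryloyl group on a fused two-ring system, and the variable part sits on a saturated ring carbon. Compound 1 `COc1ncc(C2c3ccccc3C=NN2C(=O)/C=C/c2cc(Cc3cnc(N)nc3N)cc(OC)c2OC)c(OC)n1` carries 2,4-dimethoxypyrimidin-5-yl there. In an assay on isolated protein for inhibition of Dihydrofolate reductase (Homo sapiens) (a lower number here means a stronger inhibitor, a higher number a weaker inhibitor), compound 1 gives only a limit, > 22000 nM. Compound 2 `COc1cc(Cc2cnc(N)nc2N)cc(/C=C/C(=O)N2N=Cc3ccccc3C2CCCO)c1OC` carries 3-hydroxypropyl instead, and in this assay compound 2 also gives only a limit, > 25000 nM. Compound 3 `COC(=O)C(C)(C)C1c2ccccc2C=NN1C(=O)/C=C/c1cc(Cc2cnc(N)nc2N)cc(OC)c1OC` carries 1-(methoxycarbonyl)-1-methylethyl and is a weak inhibitor in this assay at 813000 nM. The steps a step that the two limits leave unreadable from compound 1 to compound 2, a step that the limit leaves unreadable from compound 1 to compound 3 and a step that the limit leaves unreadable from compound 2 to compound 3 cannot be read in size because of the limit of > 22000 nM in this assay, at which 1 of the 3 values shown sits, and (the limit of > 25000 nM in this assay, at which 1 of the 3 values shown sits). Compound 4 `COc1cc(Cc2cnc(N)nc2N)cc(/C=C/C(=O)N2N=Cc3ccccc3C2c2ccc(CO)cc2)c1OC` is the change (4-(hydroxymethyl)phenyl in place of 2,4-dimethoxypyrimidin-5-yl on a saturated ring carbon). For the measured compounds named here, no measured step reads a size for this replacement; the three measured compounds all sit at a limit or far up the scale. Compound 4 is therefore expected to remain weak in this assay, with the estimated step that the limit leaves unreadable from compound 1 to compound 4, and an estimated value of 100000 nM between 20000 nM and 800000 nM, quite possibly reported only as a limit.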

Compound 4, half-maximal inhibitory concentration: > 23000 nM
Compound 4 gave a limit, no number; the forecaster's own chance of this, stated with the estimate: 60%; the middle value lies beyond the limit too.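

In this assay compound 4 gives only a limit, > 23000 nM, so its steps from compound 1, compound 2 and compound 3 cannot be read in size. The compounds shown leave open how far compound 1, compound 2 and compound 4 actually differ from one another or from compound 3.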